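A few compounds are considered here, and "the series" means these few. Any claim that something is new, unique, unknown or untested is made for them only; others in the source may bear on it.

Measured compounds and their values in a functional assay on HeLa cells (Homo sapiens) for inhibition; on this read-out lower numbers stand for stronger inhibition and higher numbers for weaker inhibition:
- compound 1 `Oc1ccccc1-c1cc(-c2cccc(F)c2)cc(-c2ccccc2O)n1`: > 50000 nM
- compound 2 `Oc1ccccc1-c1cc(-c2ccc(F)cc2)cc(-c2ccccc2O)n1`: > 50000 nM
- compound 3 `Oc1ccc(-c2cc(-c3cccc(F)c3)cc(-c3ccc(O)cc3)n2)cc1`: > 50000 nM

Working notes on the series.

In this assay compound 1 reaches only the limit of the assay, > 50000 nM, and not a number. Compound 2 likewise gives only a limit in this assay, > 50000 nM. For compound 3 the read-out in this assay is again a limit, > 50000 nM. All three values therefore sit at the same point: the limit of > 50000 nM in this assay, at which 3 of the 3 values shown sit.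

The change from compound 1 to compound 2 is 4-fluorophenyl in place of 3-fluorophenyl on an aromatic carbon. Its size in this assay is a step that the two limits leave unreadable from compound 1 to compound 2, because both ends sit at the limit (the limit of > 50000 nM in this assay, at which 3 of the 3 values shown sit).

How the core of compound 3 differs from the core of compound 1 is not broken down here.

Compound 4 `Oc1ccc(-c2cc(-c3ccc(F)cc3)cc(-c3ccc(O)cc3)n2)cc1` is not yet measured in this assay. It differs from compound 3 by 4-fluorophenyl in place of 3-fluorophenyl on an aromatic carbon. This is the same kind of change as from compound 1 to compound 2, but the surroundings of the place differ: in compound 1 the place is meta to two 2-hydroxyphenyl groups, in compound 3 it is meta to two 4-hydroxyphenyl groups.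

For compound 4 a step that the limit leaves unreadable from compound 3 to compound 4 is expected in this assay, resting on the unreadable step that the two limits leave unreadable from compound 1 to compound 2 and on the limit for compound 3, > 50000 nM. The estimate for compound 4 in this assay is 70000 nM, between 20000 nM and 250000 nM, most likely reported again as a limit.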

Compound 4, half-maximal inhibitory concentration: 8680 nM
Compound 4: the middle estimate sits 8.1-fold (0.91 log units) above what was measured; the measured number lies below the stated range.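

In this assay, 4-fluorophenyl in place of 3-fluorophenyl on the core of compound 3 gives an at least 5.7-fold lower number from compound 3 to compound 4 (0.76 log units; beyond the scatter), and compound 4 carries a real number, 8680 nM. Compound 3 gives only a limit, > 50000 nM, so the printed size of this step is a bound and not an exact measure. The same change from compound 1 to compound 2 cannot be read, so the series does not show whether the gain carries over from one core to the other or holds on the core of compound 3 alone, since both ends of that pair sit at the same point: the limit of > 50000 nM in this assay, at which 3 of the 4 values shown sit.

The compounds shown leave open whether the fluorine of the 4-fluorophenyl group in compound 4 matters as such, as a plain phenyl, a chlorine or a methoxy group at that place could tell. They also leave open how far the two 4-hydroxyphenyl groups of compound 4 can be changed, for instance by turning each hydroxyl into a methyl ether, an amine or a carboxylic acid.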